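A few compounds are considered here, and "the series" means these few. Any claim that something is new, unique, unknown or untested is made for them only; others in the source may bear on it.

Measured so far in an assay on isolated protein for inhibition of long-chain fatty acid transport protein 1 (Mus musculus); a higher number here means a weaker inhibitor, a lower number a stronger inhibitor:
compound 1 `CCOC(=O)c1ccc(NC(=O)CSc2nnc(CNc3ccccc3)n2CC)cc1` gives 1100 nM.
compound 2 `CCn1c(CNc2ccccc2)nnc1SCc1nc2cc(C)ccc2o1` gives the assay's limit > 10000 nM, which is not a number.
compound 3 `CCn1nnc(-c2ccc(NC(=O)CSc3nnc(CNc4ccccc4)n3CC)cc2)n1` gives the limit > 10000 nM, again not a number.

On these data alone, compound 2 thus stands at the limit, as the limit of > 10000 nM in this assay, at which 2 of the 3 values shown sit, notes; its true number is unknown. Compound 4 `CCn1c(CNc2ccccc2)nnc1SCc1nc2cc(OC(F)(F)F)ccc2o1` differs from compound 2 by trifluoromethoxy in place of methyl on an aromatic carbon. Among the compounds with values here, the one measured step, an at least 9.0-fold higher number from compound 1 to compound 3 (0.95 log units; beyond the scatter), concerns a different exchange on another part of the shared core, so no measured step bears on this swap. With compound 2 at the limit and nothing showing that this exchange shifts the number, compound 4 is expected to stay near it, the expected step being a step that the limit leaves unreadable from compound 2 to compound 4. Compound 4 is estimated at 15000 nM, between 5000 nM and 50000 nM, most likely reported again only as a limit.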

Compound 4, half-maximal inhibitory concentration: 91 nM
Compound 4: the middle estimate sits 160-fold (2.22 log units) above what was measured, and the stated range ends above it.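

In this assay, the group on this aromatic carbon clearly matters: trifluoromethoxy in place of methyl gives an at least 100-fold lower number from compound 2 to compound 4 (2.04 log units; beyond the scatter). Within the data shown here, the only earlier step was a loss at another part of the shared core, so this exchange shows that a single change can also strengthen inhibition. The full size of the step stays unknown, since compound 2 has only a limit, not a number: the limit of > 10000 nM in this assay, at which 2 of the 4 values shown sit.

On these data alone, how an amine, a carboxylic acid or a longer chain would fare on this carbon remains open. Methoxy and trifluoromethyl could show whether the oxygen or the fluorines matter more.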